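Methyl-to-hydrogen step in a homocysteine-derived thioether series

This account rests on a few compounds, and the source may have more. Where it says the series, first, only, none or still open, it means among the compounds named here.

Measured compounds:
- compound 1, `C[C@@H](NCCSCCC(N)C(=O)O)C(=O)O`, 15.5%
- compound 2, `NC(CCCSCCCC(=O)O)C(=O)O`, 5.4%

Both were tested in an assay for inhibition of betaine--homocysteine S-methyltransferase 1 (Homo sapiens), tested at 20 uM; a higher number here means more inhibition at the concentration tested (going by the name of the read-out), a lower number less inhibition. Compound 1 stands highest of the two numbers; the nearest is compound 2, whose value lies lower by a gap beyond the scatter, so the inhibition in this assay is higher for compound 1 than for compound 2. For the measured compounds named here, no step between the two measured compounds is computed, as they differ in more than one place, so only their two values can be compared.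

Compound 3, `NC(CCSCCNCC(=O)O)C(=O)O`, is not yet measured. It differs from compound 1 in a single place: hydrogen in place of methyl on a saturated chain carbon bound to an amine nitrogen and a carbonyl carbon. Going by the values given here, the two measured compounds give no step of this kind, so the expected size of the change rests on the structural change alone: a small step is expected, most likely none beyond the scatter, with a slight lean toward less inhibition, described as a number 3.5 percentage points lower from compound 1 to compound 3 (within the scatter). For compound 3 the estimated value in this assay is 12%, within an expected range from 2% to 24%.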

Compound 3, a percentage reported as inhibition, at one concentration (the size of the read-out at that concentration, not a potency): 37.1%
Beside the measured number, compound 3's estimate is 25.1 percentage points below it; measured number above the stated range.
By their numbers in this assay, from the lowest: compound 2; then compound 1; then compound 3.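

In this assay the methyl on a saturated chain carbon bound to an amine nitrogen and a carbonyl carbon turns out not to be a silent feature: hydrogen in its place gives a number 21.6 percentage points higher from compound 1 to compound 3 (beyond the scatter) and so moves the read-out in the direction of more inhibition, against the small change that might be assumed for the loss of one carbon. For the compounds shown here, this is the first step read at a single place, and it shows that the 1-carboxyethyl to carboxymethyl change alone is enough to shift the read-out at the concentration tested, which the earlier pair, differing in more than one place, could not show. No measurement at hand accounts for the direction or the size of this step.

Whether the trend runs on in the other direction is open, since an ethyl or a hydroxymethyl group on the same carbon would show if larger groups there go with less inhibition or if methyl is a special case. The read-out at one concentration also leaves open how far this step carries over to potency, which a full concentration series on compound 1 and compound 3 would settle.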